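A few compounds are considered here, and "the series" means these few. Any claim that something is new, unique, unknown or untested is made for them only; others in the source may bear on it.

For the measured compounds named here, the three compounds measured so far share one core and are all read in an ADME assay on HCT-116 cells (Homo sapiens) for cytotoxicity, read by CellTiter-Glo, with a stated time of 72 h; a higher number here means a weaker inhibitor, a lower number a stronger inhibitor. Compound 1 `Cc1ccc(-c2ccccc2S(=O)(=O)N2CCC(N3CCC(C)CC3)CC2)cc1` gives only a limit of the assay, > 5000 nM. Compound 2 `CC1CCN(C2CCN(S(=O)(=O)c3ccccc3-c3ccccc3)CC2)CC1` likewise gives only a limit, > 5000 nM. Compound 3 `Cc1ccc(C#N)c(S(=O)(=O)N2CCC(N3CCC(C)CC3)CC2)c1` gives only a limit as well, > 5000 nM. Because of the limit of > 5000 nM in this assay, at which 3 of the 3 values shown sit, compound 2 stands at the limit with the two others, and nothing about its number is known beyond that. Going by the values given here, the one step between measured compounds, a step that the two limits leave unreadable from compound 1 to compound 2, runs by hydrogen in place of methyl on an aromatic carbon, and its two limits leave its size unreadable.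

Compound 4 `COc1ccc(-c2ccccc2S(=O)(=O)N2CCC(N3CCC(C)CC3)CC2)cc1` is reached from compound 2 by methoxy in place of hydrogen on an aromatic carbon, on an aromatic carbon para to a large group; cut one bond further out the change reads phenyl to 4-methoxyphenyl. Among the compounds with values here, no measured step bears on it with a readable size, since the limit of > 5000 nM in this assay, at which 3 of the 3 values shown sit, shows that every value so far sits at the limit. With no readable step in hand, compound 4 is expected to show a step that the limit leaves unreadable from compound 2 to compound 4, none beyond the scatter. Compound 4 is therefore estimated at 10000 nM, within 4000 nM to 40000 nM, and is most likely to be reported as a limit again.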

Compound 4, half-maximal inhibitory concentration: > 5000 nM
Compound 4 gave a limit, no number; the forecaster's own chance of this, stated with the estimate: 85%; the middle value is on the limit's open side.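

Compound 4, like compound 1 and compound 2, gives only a limit in this assay, so no step among these three compounds can be read: the limit of > 5000 nM in this assay, at which 4 of the 4 values shown sit.

The compounds shown leave open whether any of them has a readable value in this assay, and how hydrogen, methyl and methoxy on the aromatic carbon compare there.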